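This account rests on a few compounds, and the source may have more. Where it says the series, first, only, none or still open, it means among the compounds named here.

In a physicochemical assay for solubility, with a stated time of 24 h (on this read-out lower numbers stand for lower solubility and higher numbers for higher solubility), compound 1 (`CCCCCc1ccc(-c2cc3cn([C@H]4C[C@H](OC(=O)[C@@H](NC(=O)[C@@H]5CCCN5C(=O)[C@@H](N)C(C)C)C(C)C)[C@@H](CO)O4)c(=O)nc3o2)cc1`) gives 5200 ug/mL as its reading. Compound 2 (`CCCCCc1ccc(-c2cc3cn([C@H]4C[C@H](O)[C@@H](COC(=O)[C@@H](NC(=O)[C@@H]5CCCN5C(=O)[C@@H](N)CC(N)=O)C(C)C)O4)c(=O)nc3o2)cc1`) gives 39000 ug/mL and compound 3 (`CCCCCc1ccc(-c2cc3cn([C@H]4C[C@H](O)[C@@H](COC(=O)[C@@H](NC(=O)[C@@H]5CCCN5C(=O)[C@@H](N)CCCCN)C(C)C)O4)c(=O)nc3o2)cc1`) gives 55000 ug/mL on the same scale. Compound 3 therefore stands well above compound 1 and within the scatter of compound 2.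

The unmeasured compound 4 (`CCCCCc1ccc(-c2cc3cn([C@H]4C[C@H](O)[C@@H](COC(=O)[C@@H](NC(=O)[C@@H]5CCCN5C(=O)[C@@H](N)CC(=O)O)C(C)C)O4)c(=O)nc3o2)cc1`) differs from compound 3 in one place: carboxy in place of 3-aminopropyl on a saturated chain carbon, two bonds along the chain from an amine nitrogen and a carbonyl carbon. Counted group by group, the difference is carboxy in place of 3-aminopropyl on a saturated chain carbon, two bonds along the chain from an amine nitrogen and a carbonyl carbon and nothing else separates the two.

Within the data shown here, only one measured step bears on this place, the swap of carbamoyl for 3-aminopropyl. Compound 1 differs from the others in more than one place, so it offers no clean comparison. Among the measured compounds shown here, no measured compound carries carboxy, so the evidence is indirect. Since a 1.4-fold higher number from compound 2 to compound 3 (0.15 log units; within the scatter) stayed small, a large move in this assay is not expected here.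

The expected step is a 1.7-fold lower number from compound 3 to compound 4 (0.24 log units; within the scatter) and it would point slightly downward without leaving the scatter. For compound 4 the estimated value is 32000 ug/mL with an expected range from 11000 ug/mL to 75000 ug/mL around it.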

Compound 4, solubility: 15000 ug/mL
Compound 4: the middle estimate sits 2.1-fold (0.33 log units) above what was measured; the measured number falls inside the stated range.
By their numbers in this assay, from the lowest: compound 1; then compound 4; then compounds 2 and 3 (each within the scatter of the next).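

In this assay, among these compounds, this position on a saturated chain carbon, two bonds along the chain from an amine nitrogen and a carbonyl carbon, now shows that a swap here can move the number beyond the scatter: carboxy in place of 3-aminopropyl gives a 3.7-fold lower number from compound 3 to compound 4 (0.56 log units; beyond the scatter), whereas the only earlier step at this place, a 1.4-fold higher number from compound 2 to compound 3 (0.15 log units; within the scatter), stayed within it. The closer comparison points the same way, since hydroxy in place of amino on a carbonyl carbon gives a 2.6-fold lower number from compound 2 to compound 4 (0.41 log units; beyond the scatter), so a change confined to the end of the group is enough to give a modest step beyond the scatter. Nothing available explains why either step goes downward, and the numbers alone record only its direction and size.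

From the compounds shown here alone, what remains open is whether the downward step depends on the length of the chain carrying the carboxylic acid, as a longer chain ending in the same group could show. Going by these compounds, it is also open whether a methyl ester at this position would stay closer to the carbamoyl group or to the carboxy group on this scale.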